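Swapping a methoxy for a dimethylamino on the aryl hydrazone

The source may hold more compounds than are shown below. What is called first, only, known or untested is meant among the compounds shown, and "the series" means these compounds.

The compounds measured so far in a functional assay on U-251 cells (Homo sapiens) for inhibition, read by sulforhodamine B assay, with a stated time of 48 h (on this read-out lower numbers stand for stronger inhibition of growth and higher numbers for weaker inhibition of growth), are:
compound 1 `CC1=CC[C@H](C(C)(C)NC(=S)N/N=C/c2ccccc2)CC1`, giving 71400 nM;
compound 2 `COc1ccc(/C=N/NC(=S)NC(C)(C)[C@H]2CC=C(C)CC2)cc1`, giving 71900 nM;
compound 3 `CC1=CC[C@H](C(C)(C)NC(=S)N/N=C/c2ccccc2O)CC1`, giving 10600 nM.

Compound 2 carries the highest number of the three. Its nearest neighbour is compound 1, since the step from compound 1 to compound 2 is a 1.0-fold higher number from compound 1 to compound 2 (0.00 log units; within the scatter); its furthest is compound 3, the step from compound 2 to compound 3 being a 6.8-fold lower number from compound 2 to compound 3 (0.83 log units; beyond the scatter). The hydroxy variant compound 3 also separates from compound 1 by a 6.7-fold lower number from compound 1 to compound 3 (0.83 log units; beyond the scatter).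

Compound 4 `CC1=CC[C@H](C(C)(C)NC(=S)N/N=C/c2ccc(N(C)C)cc2)CC1` differs from compound 2 in one place: dimethylamino in place of methoxy on an aromatic carbon. Going by the values given here, the step that bears most directly on it is the one from compound 1 to compound 2, where putting a methoxy on that aromatic carbon left the number unchanged within the scatter. The steps to compound 3 concern a hydroxy at another place on the ring and say little about this substitution. Among the compounds with values here, no measured pair shows a dimethylamino at all.

Compound 4 is therefore expected to stay close to compound 2, with a step of a 1.2-fold lower number from compound 2 to compound 4 (0.08 log units; within the scatter), well within the scatter. The estimate for compound 4 in this assay is 60000 nM, with a range from 20000 nM to 180000 nM.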

Compound 4, concentration for total growth inhibition: > 100000 nM
Compound 4 ended at the assay's limit; the forecaster's own chance of this, stated with the estimate: 20%; middle value at least 1.6-fold (0.22 log units) from the limit.
By their numbers in this assay, from the lowest: compound 3; then compounds 1 and 2 (each within the scatter of the next). At a limit, above all of these: compound 4.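

In this assay compound 4 gives > 100000 nM, which is a limit of the assay and not a number. Read from that limit, the change appears as an at least 1.3-fold higher number from compound 2 to compound 4 (0.14 log units; that floor lies within the scatter) and as an at least 1.4-fold higher number from compound 1 to compound 4 (0.14 log units; that floor lies within the scatter), so dimethylamino on this aromatic carbon, para to a large group, brings the number down against neither methoxy nor hydrogen, although both floors lie within the scatter and the true size of either step stays unknown. The earlier compounds showed only that methoxy at this place matched hydrogen, with a 1.0-fold higher number from compound 1 to compound 2 (0.00 log units; within the scatter); compound 4 adds that a second group here also fails to lower the number, and it is the only compound shown that reaches the limit: the limit of > 100000 nM in this assay, at which 1 of the 4 values shown sits.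

As far as these compounds go, how far compound 4 lies past its limit remains open, so dimethylamino cannot yet be separated from methoxy or hydrogen by size of effect. Also open, from the compounds shown here alone, is what a primary amine or a carboxylic acid on this aromatic carbon would give, and whether a hydroxy placed here would match the number of compound 3, which carries its hydroxy elsewhere on the ring.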